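Swapping the Amide Cap: What to Expect for Compound 3

The source may report more compounds than this note shows. Statements on the series, on what has been measured and on what is new or still open speak of the compounds shown alone.

Measured so far:
compound 1 `Cc1ccccc1C(=O)Nc1cccc(-c2oc3cc(-c4ccc(F)cc4)ccc3c(=O)c2O)c1` — 19400 nM
compound 2 `O=C(Nc1cccc(-c2oc3cc(-c4ccc(F)cc4)ccc3c(=O)c2O)c1)c1cc(F)cc(F)c1` — 4960 nM

Both compounds share one core and differ only in the aromatic group attached to the amide carbonyl. Going by the values given here, in a functional assay on HepG2 cells (Homo sapiens) for antiproliferative activity, read by CCK-8 assay, with a stated time of 72 h (on this read-out lower numbers stand for stronger inhibition and higher numbers for weaker inhibition), compound 1 gives 19400 nM, the highest of the two numbers; its only neighbour is compound 2, reached by a 3.9-fold lower number from compound 1 to compound 2 (0.59 log units; beyond the scatter), a modest but real change.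

Compound 3 `N#Cc1ccc(C(=O)Nc2cccc(-c3oc4cc(-c5ccc(F)cc5)ccc4c(=O)c3O)c2)cc1` has not yet been measured. It differs from compound 1 in one place: 4-cyanophenyl in place of 2-methylphenyl on a carbonyl carbon. Among the compounds with values here, the only measured step that bears on this change is a 3.9-fold lower number from compound 1 to compound 2 (0.59 log units; beyond the scatter), in which another substituted phenyl also replaced the 2-methylphenyl on the carbonyl carbon and the number fell. A 4-cyanophenyl is a different group, so one step is a thin basis, but the direction it suggests is downward. The step expected is a 2.8-fold lower number from compound 1 to compound 3 (0.44 log units; beyond the scatter), a modest lowering of the same order. Compound 3 is therefore estimated to give 7000 nM, with a range from 2500 nM to 20000 nM.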

Compound 3, half-maximal inhibitory concentration: 7110 nM
Estimate against measurement, compound 3: 1.0-fold (0.01 log units) below; the range from low to high includes it.
By their numbers in this assay, from the lowest: compounds 2 and 3 (each within the scatter of the next); then compound 1.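

The 4-cyanophenyl group gives a second replacement for 2-methylphenyl on this carbonyl carbon, and in this assay it also lowers the number, with a 2.7-fold lower number from compound 1 to compound 3 (0.44 log units; beyond the scatter), so the lowering seen earlier is no longer tied to a single replacement group. The two replacement groups differ in their substituents and where those substituents sit, yet a 1.4-fold higher number from compound 2 to compound 3 (0.16 log units; within the scatter) leaves them within the usual scatter, so this assay cannot put one ahead of the other, while the compound carrying 2-methylphenyl stays apart from both with the highest number of the three. No measurement shown here explains why the number changes at this position, and the result records only the size of each step.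

The compounds shown leave open whether the lowering reflects the loss of 2-methylphenyl or something the two entering groups have in common. A plain phenyl with no substituent on the same carbonyl carbon would help separate those two readings, and a cap bearing an amine or a carboxylic acid would test how far this position tolerates groups of a quite different kind.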